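The source may report more compounds than this note shows. Statements on the series, on what has been measured and on what is new or still open speak of the compounds shown alone.

Measured in a functional assay on M21 cells (Homo sapiens) for inhibition, read by sulforhodamine B assay, with a stated time of 48 h; a higher number here means a weaker inhibitor of growth, a lower number a stronger inhibitor of growth:
Compound 1, `O=C(CCl)NC(=O)Nc1ccc2c(c1)CCC2`: 1700 nM
Compound 2, `O=C(CCl)NC(=O)Nc1ccc(-c2ccccc2)cc1`: 1400 nM

In this assay, compound 2 gives 1400 nM and compound 1 gives 1700 nM. These two values lie within the usual scatter of each other, so compound 2 stands level with compound 1 and neither can be ranked above the other.

The next compound is compound 3, `Cc1ccc(NC(=O)NC(=O)CCl)cc1`, which has methyl in place of phenyl on an aromatic carbon, para to a group of 8 heavy atoms: methyl in place of phenyl on an aromatic carbon. Its value is not yet known. Among the measured compounds shown here, no pair of measured compounds differs in one place only, so the data offer no direct precedent for this change. For the measured compounds named here, the only anchors are compound 2 at 1400 nM and compound 1 at 1700 nM, and both carry more heavy atoms than compound 3. A modest shift towards weaker inhibition of growth therefore seems likely, and it is estimated as a 2.1-fold higher number from compound 2 to compound 3 (0.33 log units; beyond the scatter). For compound 3 the expected value is 3000 nM, with an estimated range of 1200 nM to 7500 nM.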

Compound 3, concentration for 50% growth inhibition: 4900 nM
Beside the measured number, compound 3's estimate is 1.6-fold (0.21 log units) below it; low and high end bracket the measured number.
By their numbers in this assay, from the lowest: compounds 2 and 1 (each within the scatter of the next); then compound 3.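

Replacing phenyl with methyl on this aromatic carbon, para to a group of 8 heavy atoms, gives a 3.5-fold higher number from compound 2 to compound 3 (0.54 log units; beyond the scatter) in this assay. This is the first change in one place only among the compounds shown, and it establishes that the group at this position affects growth inhibition in these cells: with methyl here, inhibition is weaker than with phenyl. The step still cannot separate the loss of the aromatic ring from the loss of heavy atoms, as these two differences arrive together in a single change, and no measurement at hand accounts for the shift.

The compounds shown leave open how growth inhibition changes across the range between methyl and phenyl at this position, for example with an ethyl, isopropyl or cyclohexyl group, and whether a methoxy group, an amine or a carboxylic acid in the same place would fit the same trend. They also leave open whether the chloroacetyl end of the shared core matters, for example when bromine replaces its chlorine, or a plain acetyl group replaces it altogether.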